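Removing a chloro group from the urea aryl of compound 3

The compounds below may be only part of what the source reports. "The series", "measured", "known", "first", "only" and "open" are said of these compounds alone.

Three compounds share one core and were tested in a functional assay on Hs-578T cells (Homo sapiens) for inhibition, read by sulforhodamine B assay, with a stated time of 48 h, tested at 10 uM; on this read-out lower numbers stand for a stronger effect and higher numbers for a weaker effect at the one concentration tested. Compound 1 `O=C(Nc1cccc(-n2cc(-c3ccncc3)c(-c3cc(O)cc(Cl)c3)n2)c1)Nc1ccc(Cl)c(C(F)(F)F)c1` gives 21.7%. Among the compounds with values here, compound 2 `O=C(Nc1cccc(-n2cc(-c3ccncc3)c(-c3cc(O)cc(Cl)c3)n2)c1)Nc1ccc(Cl)c(Cl)c1` gives -6.42%; the step of a number 28.1 percentage points lower from compound 1 to compound 2 (beyond the scatter) is the one measured change on the urea-bearing aryl ring. Compound 3 `COc1cc(Cl)cc(-c2nn(-c3cccc(NC(=O)Nc4ccc(Cl)c(C(F)(F)F)c4)c3)cc2-c2ccncc2)c1` gives 14.6%, and the step of a number 7.1 percentage points lower from compound 1 to compound 3 (within the scatter) shows that the methoxy for hydroxy swap on the other ring changed little. Among the three numbers compound 3 stands second highest, close to compound 1 and well apart from compound 2.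

Compound 4 `COc1cc(Cl)cc(-c2nn(-c3cccc(NC(=O)Nc4cccc(C(F)(F)F)c4)c3)cc2-c2ccncc2)c1` differs from compound 3 in one place: hydrogen in place of chloro on an aromatic carbon. Within the data shown here, no measured pair removes this chloro outright, so the nearest guide is the step from compound 1 to compound 2, where a change at the same carbon moved the number by a modest amount. A shift of similar or smaller size is therefore expected in this assay, with the direction uncertain, since removing a group is not the same as exchanging it. The expected step is a number 6.6 percentage points lower from compound 3 to compound 4 (within the scatter). Compound 4 is thus estimated at 8%, most likely between -18% and 34%.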

Compound 4, a percentage reported as activity, at one concentration (the size of the read-out at that concentration, not a potency): 23.2%
For compound 4 the middle estimate is 15.2 percentage points below the measured one; the range from low to high includes it.
By their numbers in this assay, from the lowest: compound 2; then compounds 3, 1 and 4 (each within the scatter of the next).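

In this assay, taking the chloro off the 4-chloro-3-(trifluoromethyl)phenyl group, at the carbon ortho to the trifluoromethyl group, gives a number 8.6 percentage points higher from compound 3 to compound 4 (within the scatter). Within the data shown here, this is the first look at this carbon alone, since the earlier change on this ring, a number 28.1 percentage points lower from compound 1 to compound 2 (beyond the scatter), exchanged the trifluoromethyl group and kept the chloro; here, with the methoxy compounds, hydrogen and chloro on this carbon cannot be told apart in this read-out, so the chloro is not needed to keep the read-out of compound 3. No measurement at hand explains why this position tolerates the loss of the chloro.

Going by these compounds, whether the same removal would read the same way in compound 1, which carries hydroxy in place of methoxy, or in compound 2, whose read-out is the only one here set apart beyond the scatter, stays open. Also open, on these data alone, is what other groups on this carbon would do, such as a fluoro, a methyl, an amine or a carboxylic acid, since hydrogen and chloro are the only two compared here, and only at the one concentration tested.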